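The source may report more compounds than this note shows. Statements on the series, on what has been measured and on what is new or still open speak of the compounds shown alone.

Compound 1 `CC(C)=CCC/C(C)=C/CC/C(C)=C/CC[C@@H]1[C@@]2(C)CCC(=O)C(C)(C)[C@@H]2CC[C@@]1(C)O` is the unmodified ketone of this series. In a functional assay on HeLa cells (Homo sapiens) for cytotoxicity, read by MTT assay, with a stated time of 48 h (on this read-out lower numbers stand for stronger inhibition and higher numbers for weaker inhibition), compound 1 gives 18300 nM. Compound 2 `CC(C)=CCC/C(C)=C/CC/C(C)=C/CC[C@@H]1[C@@]2(C)CC/C(=N\OCc3cn(-c4ccc(Cl)cc4)nn3)C(C)(C)[C@@H]2CC[C@@]1(C)O` carries an oxime ether bearing a triazole with a 4-chlorophenyl group on its aromatic nitrogen, and in this assay compound 2 gives 14800 nM. Compound 3 `CC(C)=CCC/C(C)=C/CC/C(C)=C/CC[C@@H]1[C@@]2(C)CC/C(=N\OCc3cn(-c4ccccc4C#N)nn3)C(C)(C)[C@@H]2CC[C@@]1(C)O` has 2-cyanophenyl in that position, and in this assay compound 3 gives 21200 nM. All three numbers lie within the usual scatter of one another, so compound 3 cannot be separated from compound 1 or from compound 2 on these data.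

Compound 4 `CC(C)=CCC/C(C)=C/CC/C(C)=C/CC[C@@H]1[C@@]2(C)CC/C(=N\OCc3cn(-c4ccc(F)c(Cl)c4)nn3)C(C)(C)[C@@H]2CC[C@@]1(C)O` is the next member. It differs from compound 3 in one place: 3-chloro-4-fluorophenyl in place of 2-cyanophenyl on an aromatic nitrogen. Within the data shown here, the only measured step that bears on this change is the one from compound 2 to compound 3, which also swaps the aryl group on the same aromatic nitrogen; there it gave a 1.4-fold higher number from compound 2 to compound 3 (0.16 log units; within the scatter). Since that exchange of one aryl group for another left the number within the scatter, the expectation for compound 4 in this assay is a step of a 1.2-fold lower number from compound 3 to compound 4 (0.07 log units; within the scatter), in no direction beyond the scatter. Compound 4 is therefore estimated at 18000 nM, with a range from 9000 nM to 36000 nM.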

Compound 4, half-maximal inhibitory concentration: 20100 nM
Compound 4: middle estimate off by 1.1-fold (0.05 log units), on the low side, within the range that was stated.
By their numbers in this assay, from the lowest: compounds 2, 1, 4 and 3 (each within the scatter of the next).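

In this assay, 3-chloro-4-fluorophenyl in place of 2-cyanophenyl gives a 1.1-fold lower number from compound 3 to compound 4 (0.02 log units; within the scatter), and 3-chloro-4-fluorophenyl in place of 4-chlorophenyl gives a 1.4-fold higher number from compound 2 to compound 4 (0.13 log units; within the scatter). Together with the earlier step, this means that all three aryl groups on this aromatic nitrogen of the five-membered ring now lie within the scatter of one another, so neither giving up the nitrile, with its triple bond and hydrogen-bond acceptor, for chlorine and fluorine, nor adding fluorine to a chlorophenyl group with its chlorine placed differently, leaves a difference that can be read at this position.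

All three groups compared here are substituted phenyl rings, so these data describe only a narrow part of what this position could carry. As far as these compounds go, whether an amine or a carboxylic acid on the phenyl ring, or a longer alkyl chain in place of the ring, would give a step beyond the scatter remains open. No measurement at hand offers an explanation for how closely these numbers lie together.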